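Capping the free hydroxy group of compound 3

The compounds below may be only part of what the source reports. "The series", "measured", "known", "first", "only" and "open" are said of these compounds alone.

In a functional assay on HeLa cells (Homo sapiens) for cytotoxicity (on this read-out higher numbers stand for weaker inhibition and lower numbers for stronger inhibition), compound 1 `C/C=C/C(=O)OCC1=CCC(C)(C)CC1=O` gives 4.7 ug/mL, and compound 2 `CC1(C)CC=C(CI)C(=O)C1` gives 2.3 ug/mL. Compound 3 `CC1(C)CC=C(CO)C(=O)C1` reads > 100 ug/mL, which is a limit of the assay and not a number. Going by these compounds, it stands as the weakest of the three, and its true value is unknown.

Compound 4 `CC(=O)OCC1=CCC(C)(C)CC1=O` turns hydroxy to acetoxy, with acetyl in place of hydrogen on an oxygen on a saturated carbon. Within the data shown here, two measured steps bear on this. The closer one is an at least 21-fold higher number from compound 1 to compound 3 (1.32 log units; beyond the scatter), which removes (prop-1-en-1-yl)carbonyl from that same oxygen. The other is an at least 43-fold higher number from compound 2 to compound 3 (1.63 log units; beyond the scatter), with hydroxy in place of iodo. Both are large, and both end at the limit of compound 3. Acetyl on that oxygen should therefore largely reverse the first step, although acetyl is not the same group as the one in compound 1. The expected step is an at least 12-fold lower number from compound 3 to compound 4 (1.09 log units; beyond the scatter), towards stronger inhibition. For compound 4 the estimated value is 8 ug/mL, with an expected range of 3 ug/mL to 30 ug/mL.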

Compound 4, half-maximal inhibitory concentration: 23.5 ug/mL
The estimate for compound 4 lay 2.9-fold (0.47 log units) below the measured number; measured number inside the range.
By their numbers in this assay, from the lowest: compound 2; then compound 1; then compound 4. At a limit, above all of these: compound 3.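

In this assay, acetyl on the oxygen already moves the read-out towards stronger inhibition, and the piece shows an at least 4.2-fold lower number from compound 3 to compound 4 (0.62 log units; beyond the scatter) on this change alone. The acyl group itself also counts, since methyl in place of prop-1-en-1-yl on the carbonyl carbon gives a 5.0-fold higher number from compound 1 to compound 4 (0.70 log units; beyond the scatter) and acetoxy in place of iodo gives a 10-fold higher number from compound 2 to compound 4 (1.01 log units; beyond the scatter) on the same core, so capping the hydroxy does not by itself reach the level of compound 1 or compound 2. Compound 3 stands at a limit, so the first of these steps is only a bound: the limit of > 100 ug/mL in this assay, at which 1 of the 4 values shown sits.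

Going by these compounds, whether the carbonyl of the ester is needed stays open, as a methyl ether on this oxygen or an amine in its place would show. On these data alone, whether the double bond in prop-1-en-1-yl matters also stays open, as a saturated propyl chain on the carbonyl carbon would show.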